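A few compounds are considered here, and "the series" means these few. Any claim that something is new, unique, unknown or untested is made for them only; others in the source may bear on it.

Measured compounds:
compound 1, `Cn1ccc2c(Oc3ccc(NC(=O)c4cn(-c5ccc(F)cc5)c5ccccc5c4=O)cc3F)ccnc21`: in a functional assay on MCF7 cells (Homo sapiens) for inhibition, read by MTT assay, with a stated time of 72 h (a higher number here means a weaker inhibitor, a lower number a stronger inhibitor), compound 1 gives "not determined" (no result reported)
compound 2, `O=C(Nc1ccc(Oc2ccnc3[nH]ccc23)c(F)c1)c1cn(-c2ccc(F)cc2)c2ccccc2c1=O`: in this assay compound 2 gives 520 nM

Among the compounds with values here, compound 2 holds the only number here, so nothing shows how it ranks against another compound. Compound 3, `COc1ccc(-n2cc(C(=O)Nc3ccc(Oc4ccnc5[nH]ccc45)c(F)c3)c(=O)c3ccccc32)cc1`, differs from compound 2 in one place: methoxy in place of fluoro on an aromatic carbon. Within the data shown here, no measured pair shows this kind of change, so the step is expected to stay within the scatter of this assay, with no clear direction. For compound 3 the expected result is 600 nM, within 200 nM to 2000 nM. The expected step is a 1.2-fold higher number from compound 2 to compound 3 (0.06 log units; within the scatter).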

Compound 3, half-maximal inhibitory concentration: 6620 nM
Estimate against measurement, compound 3: 11-fold (1.04 log units) below, outside the stated range (above it).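

In this assay, replacing 4-fluorophenyl with 4-methoxyphenyl gives a 13-fold higher number from compound 2 to compound 3 (1.10 log units; beyond the scatter), a large loss of inhibition. Within the data shown here, this is the first sign that this position, para to a large group, is sensitive to what sits on it: a change from one heavy atom to two is enough to weaken the compound well beyond the usual scatter. Nothing available here explains the size of this step. As far as these compounds go, whether an amine, a hydroxyl or chlorine at this position would behave more like fluoro or more like methoxy remains open.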